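This account rests on a few compounds, and the source may have more. Where it says the series, first, only, none or still open, it means among the compounds named here.

Within the data shown here, in a functional assay on a cell-free system (plasma, Homo sapiens) for inhibition, with Plasma (Rattus norvegicus) as the target (a higher number here means a weaker inhibitor, a lower number a stronger inhibitor), compound 2 `CCCOc1ccc2c(N3CCNCC3)cc(=O)oc2c1C` gives 7770 nM, the higher of the two numbers so far, while compound 1 `Cc1c(OCc2cccnc2)ccc2c(N3CCNCC3)cc(=O)oc12` gives 1420 nM. Compound 3 `CCCCOc1ccc2c(N3CCNCC3)cc(=O)oc2c1C` differs from compound 2 by methyl in place of hydrogen on a saturated chain carbon, three bonds along the chain from an oxygen on an aromatic ring, with methyl in place of hydrogen, which turns propyl to butyl. Among the measured compounds shown here, only one measured step bears on this: a 5.5-fold higher number from compound 1 to compound 2 (0.74 log units; beyond the scatter), where ethyl replaced pyridin-3-yl, a much bigger exchange than this one. No step beyond the scatter is therefore expected, only an estimated 1.4-fold lower number from compound 2 to compound 3 (0.15 log units; within the scatter). For compound 3 the expected value is 5500 nM, with an estimated range from 2200 nM to 13000 nM.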

Compound 3, half-maximal inhibitory concentration: 5030 nM
The estimate for compound 3 lay 1.1-fold (0.04 log units) above the measured number; the range from low to high includes it.
By their numbers in this assay, from the lowest: compound 1; then compounds 3 and 2 (each within the scatter of the next).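

In this assay the change from propyl to butyl gives a 1.5-fold lower number from compound 2 to compound 3 (0.19 log units; within the scatter) and so does not separate the two compounds, which shows that methyl in place of hydrogen three bonds along the chain from an oxygen on an aromatic ring has no effect beyond the scatter. Compound 1 also stays clear of the butyl compound, with a 3.5-fold higher number from compound 1 to compound 3 (0.55 log units; beyond the scatter) as the step. Nothing available explains either step.

Still open, going by these compounds, is whether a longer chain than butyl would behave the same way. The compounds shown also leave open whether an amine or a carboxylic acid in its place would bring the number nearer that of compound 1.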